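A few compounds are considered here, and "the series" means these few. Any claim that something is new, unique, unknown or untested is made for them only; others in the source may bear on it.

Compound 2, `O=C(/C=C/c1ccc(OCc2nc(C3CCN(Cc4cccc(F)c4)CC3)no2)cc1)NO`, is an aryl-substituted analogue of compound 1, `Cc1ccccc1CN1CCC(c2noc(COc3ccc(/C=C/C(=O)NO)cc3)n2)CC1`. In an assay on isolated protein for inhibition of protein deacetylase HDAC6 (Homo sapiens), read by fluorescence, with a stated time of 1 h, tested at 100 nM (a lower number here means less inhibition, a higher number more inhibition at the concentration tested (going by the name of the read-out)), compound 1 gives 68%, and in the same assay compound 2 gives 73%; the step of a number 5 percentage points higher from compound 1 to compound 2 (within the scatter) lies within the scatter, so the two figures cannot be told apart. Compound 3, `O=C(/C=C/c1ccc(OCc2nc(C3CCN(Cc4ccc(F)c(F)c4)CC3)no2)cc1)NO`, has not yet been measured. It differs from compound 2 in one place: fluoro in place of hydrogen on an aromatic carbon. Among the measured compounds shown here, only one measured step bears on this change, the swap from 2-methylphenyl to 3-fluorophenyl that gave a number 5 percentage points higher from compound 1 to compound 2 (within the scatter), and that step was within the scatter. For the measured compounds named here, with no measured step on the benzyl ring reaching beyond the scatter, the expected step of no change at the digits printed from compound 2 to compound 3 (within the scatter) for compound 3 in this assay is none beyond the scatter. Compound 3 is therefore estimated at 73% in this assay, with a range from 58% to 85%.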

Compound 3, a percentage reported as inhibition, at one concentration (the size of the read-out at that concentration, not a potency): 60%
Compound 3: the middle estimate sits 13 percentage points above what was measured, and the stated range covers the measured number.
By their numbers in this assay, from the lowest: compounds 3, 1 and 2 (each within the scatter of the next, the first and the last beyond it).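

Among the compounds shown here, the change from 3-fluorobenzyl to 3,4-difluorobenzyl is the first step on this ring to go beyond the scatter in this assay: fluoro on the aromatic carbon ortho to a fluoro group and para to a large group gives a number 13 percentage points lower from compound 2 to compound 3 (beyond the scatter), so this position is not indifferent to substitution, even for a single fluorine. The reading depends on the comparison, though, since 3,4-difluorophenyl in place of 2-methylphenyl gives a number 8 percentage points lower from compound 1 to compound 3 (within the scatter), and the drop is therefore seen only against compound 2. Nothing given here accounts for the step.

The compounds shown leave open whether fluoro on this aromatic carbon would give a similar step without the neighbouring fluoro group. They also leave open how chloro, methoxy or an amine would fare on that same carbon.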